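Dimethoxyphenyl for dimethylphenyl on the piperazine nitrogen

A few compounds are considered here, and "the series" means these few. Any claim that something is new, unique, unknown or untested is made for them only; others in the source may bear on it.

Compound 1 `Cc1nc(-c2ccccc2)c(C(=O)N2CCN(c3cccc(C)c3C)CC2)o1` gives 0.38 ug/mL in a toxicity assay on HUVEC cells (Homo sapiens) for inhibition (a lower number here means a stronger inhibitor of growth, a higher number a weaker inhibitor of growth), the highest of the three numbers; compound 2 `COc1cc(OC)cc(N2CCN(C(=O)c3oc(C)nc3-c3ccccc3F)CC2)c1` gives 0.118 ug/mL and compound 3 `COc1cc(OC)cc(N2CCN(C(=O)c3oc(C)nc3-c3cccc(F)c3)CC2)c1` gives 0.126 ug/mL, both lower than compound 1 by more than the scatter. Going by the values given here, the only measured step, a 1.1-fold higher number from compound 2 to compound 3 (0.03 log units; within the scatter), concerns the fluorophenyl and not the amine-nitrogen aryl group. Compound 4 `COc1cc(OC)cc(N2CCN(C(=O)c3oc(C)nc3-c3ccccc3)CC2)c1` differs from compound 1 by 3,5-dimethoxyphenyl in place of 2,3-dimethylphenyl on an amine nitrogen in a ring. Among the compounds with values here, no measured step covers this change directly; compounds 2 and 3 carry the same 3,5-dimethoxyphenyl and sit close together. The expectation is a step of a 2.5-fold lower number from compound 1 to compound 4 (0.40 log units; beyond the scatter), downward, beyond the scatter. Compound 4 is therefore estimated at 0.15 ug/mL, with a range from 0.06 ug/mL to 0.4 ug/mL.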

Compound 4, concentration for 50% growth inhibition: 0.319 ug/mL
The estimate for compound 4 lay 2.1-fold (0.33 log units) below the measured number, and the stated range covers the measured number.
By their numbers in this assay, from the lowest: compounds 2 and 3 (each within the scatter of the next); then compounds 4 and 1 (each within the scatter of the next).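

In this assay, the exchange on the amine nitrogen in a ring gives a 1.2-fold lower number from compound 1 to compound 4 (0.08 log units; within the scatter), so this aryl swap alone does not separate the two compounds. The fluoro does separate compounds, since removing it gives a 2.5-fold higher number from compound 3 to compound 4 (0.40 log units; beyond the scatter) and a 2.7-fold higher number from compound 2 to compound 4 (0.43 log units; beyond the scatter), with either fluoro position giving a similar gap. No evidence on the origin of these steps is available. On these data alone, whether fluoro has the same effect with 2,3-dimethylphenyl on the piperazine nitrogen remains open. So does the outcome with chloro or methoxy in place of fluoro on the phenyl ring.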